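Aryl ketone variation on the benzoxaborole chalcone series

The source may hold more compounds than are shown below. What is called first, only, known or untested is meant among the compounds shown, and "the series" means these compounds.

Measured so far:
compound 1 `O=C(/C=C/c1ccc2c(c1)B(O)OC2)c1ccc(-c2ccccc2)cc1` — 9500 nM
compound 2 `O=C(/C=C/c1ccc2c(c1)B(O)OC2)c1ccco1` — 24100 nM
compound 3 `O=C(/C=C/c1ccc2c(c1)B(O)OC2)c1ccc(OCc2ccccc2)cc1` — 12100 nM

The three compounds share one core and differ only in the group on the carbonyl carbon. In a functional assay on HCT-116 cells (Homo sapiens) for cytotoxicity, read by MTT assay, with a stated time of 48 h (a higher number here means a weaker inhibitor, a lower number a stronger inhibitor), compound 1 gives 9500 nM, compound 3 gives 12100 nM and compound 2 gives 24100 nM. Compound 2 carries the highest number of the three; its gap to compound 3 is within the scatter, its gap to compound 1 beyond it. Among the measured compounds shown here, the one single-point step, a 1.3-fold higher number from compound 1 to compound 3 (0.11 log units; within the scatter), lies within the scatter.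

Compound 4 `Cc1cccc(C(=O)/C=C/c2ccc3c(c2)B(O)OC3)c1` is not yet measured. Relative to compound 2 it carries 3-methylphenyl in place of furan-2-yl on a carbonyl carbon. For the measured compounds named here, no measured step exchanges a furan-2-yl for a six-membered aromatic ring of carbon only, so the change has no direct precedent; what exists is that compound 1 and compound 3, both carrying such a ring, sit at lower numbers than compound 2, while the step from compound 1 to compound 3 shows the ring's substituent matters little. Compound 4 is therefore expected near the numbers of compound 1 and compound 3, a step of a 2.2-fold lower number from compound 2 to compound 4 (0.34 log units; beyond the scatter) in this assay toward a lower number. Compound 4 is estimated at 11000 nM, with a range from 5500 nM to 22000 nM.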

Compound 4, half-maximal inhibitory concentration: 6700 nM
For compound 4 the middle estimate is 1.6-fold (0.22 log units) above the measured one; the range from low to high includes it.
By their numbers in this assay, from the lowest: compounds 4, 1, 3 and 2 (each within the scatter of the next, the first and the last beyond it).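

In this assay, among the compounds shown here, 3-methylphenyl in place of furan-2-yl on a carbonyl carbon gives a 3.6-fold lower number from compound 2 to compound 4 (0.56 log units; beyond the scatter) and is the only single-point step at this position that lies beyond the scatter. The earlier compounds shown here allowed only an indirect reading of furan-2-yl against rings of carbon only, since compound 1 and compound 3 each differ from compound 2 by a larger substituted ring. This direct exchange shows that the position responds to replacing a five-membered aromatic ring with 1 hetero atom by a six-membered aromatic ring of carbon only, although a single pair cannot separate the ring exchange from the added methyl.

A plain phenyl, a thiophen-2-yl, or a ring bearing an amine or a carboxylic acid would test how far this response extends. What lies behind the step remains unexplained, with no supporting data available in the compounds shown.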